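The compounds below may be only part of what the source reports. "The series", "measured", "known", "first", "only" and "open" are said of these compounds alone.

Working notes, benzylamine series on the shared core of compound 3 `CN(CCCn1c(=O)oc2ccccc21)Cc1ccccc1`. Among the three compounds measured in an assay on membranes from liver for displacement of a labelled ligand from Sigma non-opioid intracellular receptor 1 (Rattus norvegicus), read by scintillation counting (on this read-out higher numbers stand for weaker inhibition and lower numbers for stronger inhibition), compound 3 gives 223 nM and stands lowest. Compound 2 `Cc1ccc(CN(C)CCCn2c(=O)oc3ccccc32)cc1` gives 871 nM in this assay, and compound 1 `CN(CCCn1c(=O)oc2ccccc21)Cc1cccc(Cl)c1` gives 3230 nM. Both steps from compound 3 are beyond the scatter: a 3.9-fold lower number from compound 2 to compound 3 (0.59 log units; beyond the scatter) and a 14-fold lower number from compound 1 to compound 3 (1.16 log units; beyond the scatter).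

Compound 4 `Cc1cccc(CN(C)CCCn2c(=O)oc3ccccc32)c1` is not yet measured. Relative to compound 3 the change is methyl in place of hydrogen on an aromatic carbon, so the entering group is the same methyl that compound 2 carries, but at the place where compound 1 carries its chloro, meta to a large group.

Among the compounds with values here, two measured steps bear on this. The step of a 3.9-fold lower number from compound 2 to compound 3 (0.59 log units; beyond the scatter) shows that a methyl on the ring, at a different place, raised the number by a modest amount; the step of a 14-fold lower number from compound 1 to compound 3 (1.16 log units; beyond the scatter) shows that a chloro at the very place now in question raised it by a large amount. Any substituent on the ring has so far cost affinity in this assay, and compound 3 stays the outlier with the bare phenyl.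

Compound 4 is therefore expected to sit above compound 3, with the step of a 4.0-fold higher number from compound 3 to compound 4 (0.61 log units; beyond the scatter) estimated as modest, between the two precedents. The estimate for compound 4 in this assay is 900 nM, within 300 nM to 2700 nM.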

Compound 4, inhibition constant: 1840 nM
For compound 4 the middle estimate is 2.0-fold (0.31 log units) below the measured one, within the range that was stated.
By their numbers in this assay, from the lowest: compound 3; then compound 2; then compounds 4 and 1 (each within the scatter of the next).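

On the ring of compound 3, a methyl at the place where compound 1 carries its chloro costs far more than the small entering group alone might suggest in this assay (an 8.3-fold higher number from compound 3 to compound 4 (0.92 log units; beyond the scatter)), and methyl and chloro at this place cannot be told apart (a 1.8-fold lower number from compound 1 to compound 4 (0.24 log units; within the scatter)). The earlier compounds shown here could not separate the effect of the place from that of the group, but the two methyl isomers can: moving from 4-methylphenyl to 3-methylphenyl alone gives a step beyond the scatter (a 2.1-fold higher number from compound 2 to compound 4 (0.32 log units; beyond the scatter)), so at least for methyl, the place on the ring matters and not only the presence of a substituent. Nothing measured here accounts for this difference between the two places.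

From the compounds shown here alone, whether a fluoro, a methoxy or a hydroxy at this place would give a number near those of compound 1 and compound 4 or nearer that of compound 3 stays open. Also open, going by these compounds, are how a chloro would behave at the place where compound 2 carries its methyl, and whether the same ring preferences would hold with a longer chain to the shared core.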